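The source may hold more compounds than are shown below. What is called first, only, known or untested is meant among the compounds shown, and "the series" means these compounds.

In a functional assay on THP-1 cells (Homo sapiens) for cytotoxicity, read by MTT assay, with a stated time of 24 h (on this read-out lower numbers stand for stronger inhibition and higher numbers for weaker inhibition), compound 1 `CN1C/C(=C\c2ccc(Cl)cc2)C(=O)/C(=C/c2cccc([N+](=O)[O-])c2)C1` gives 7870 nM and compound 2 `CN1C/C(=C\c2cccc([N+](=O)[O-])c2)C(=O)/C(=C/c2ccc(Cl)cc2Cl)C1` gives 3560 nM, the lower of these two numbers. Compound 3 `CN1C/C(=C\c2cccc(Br)c2)C(=O)/C(=C/c2cccc([N+](=O)[O-])c2)C1` differs from compound 2 as follows: 3-bromophenyl in place of 2,4-dichlorophenyl on a double-bonded chain carbon bound to a double-bonded ring carbon, with 3-bromophenyl in place of 2,4-dichlorophenyl on a double-bonded chain carbon bound to a double-bonded ring carbon. Going by the values given here, the one measured step that bears on this, a 2.2-fold lower number from compound 1 to compound 2 (0.34 log units; beyond the scatter), is modest and came with chloro in place of hydrogen on an aromatic carbon. With the chloro groups leaving, a similarly modest move to a higher number is expected in this assay, and the estimated step is a 2.1-fold higher number from compound 2 to compound 3 (0.32 log units; beyond the scatter). For compound 3 the expected value is 7500 nM, with an estimated range of 3000 nM to 17000 nM.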

Compound 3, half-maximal inhibitory concentration: 4030 nM
Estimate against measurement, compound 3: 1.9-fold (0.27 log units) above, within the range that was stated.
By their numbers in this assay, from the lowest: compounds 2, 3 and 1 (each within the scatter of the next, the first and the last beyond it).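

In this assay the change from 2,4-dichlorophenyl to 3-bromophenyl at this place gives a 1.1-fold higher number from compound 2 to compound 3 (0.05 log units; within the scatter) and so one bromine serves about as well here as two chlorines. The change from 4-chlorophenyl to 3-bromophenyl gives a 2.0-fold lower number from compound 1 to compound 3 (0.29 log units; within the scatter) and so compound 3 sits within the scatter of both compound 1 and compound 2, even though those two lie beyond the scatter of each other. Nothing available explains these results. On these data alone, what a phenyl group carrying an amine or a carboxylic acid instead of a halogen would do at this place stays open.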